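Trimming the Sulfonamide Chain Down to Bare Sulfamoyl

A few compounds are considered here, and "the series" means these few. Any claim that something is new, unique, unknown or untested is made for them only; others in the source may bear on it.

Among the measured compounds shown here, compound 2 `CCCCNS(=O)(=O)c1ccc(Nc2ncc3c(n2)N(c2ccn(C)n2)C(CC)C(=O)N3C)cc1` gives 191 nM in an assay for inhibition of serine/threonine-protein kinase PLK2 (Homo sapiens), read by FRET and Z'-LYTE, with a stated time of 1 h (on this read-out higher numbers stand for weaker inhibition and lower numbers for stronger inhibition), the lower of the two numbers measured so far. Compound 1 `CCC1C(=O)N(C)c2cnc(Nc3ccc(S(=O)(=O)NCCO)cc3)nc2N1c1ccn(C)n1` gives 478 nM in this assay. For the measured compounds named here, the only measured step, a 2.5-fold lower number from compound 1 to compound 2 (0.40 log units; beyond the scatter), altered the chain on the sulfonamide nitrogen but kept it. Compound 3 `CCC1C(=O)N(C)c2cnc(Nc3ccc(S(N)(=O)=O)cc3)nc2N1c1ccn(C)n1` instead removes that chain: hydrogen in place of butyl on a sulfonamide nitrogen. That measured step offers only loose guidance here, since butyl has so far read as helpful. Compound 3 is therefore expected to give 450 nM in this assay, within 170 nM to 1200 nM, a step estimated at a 2.4-fold higher number from compound 2 to compound 3 (0.37 log units; beyond the scatter).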

Compound 3, half-maximal inhibitory concentration: 121 nM
The estimate for compound 3 lay 3.7-fold (0.57 log units) above the measured number; measured number below the stated range.
By their numbers in this assay, from the lowest: compounds 3 and 2 (each within the scatter of the next); then compound 1.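

At the sulfonamide nitrogen, the chain turns out not to be needed to hold this level of inhibition in this assay: hydrogen in place of butyl gives a 1.6-fold lower number from compound 2 to compound 3 (0.20 log units; within the scatter) and so cannot be told apart from butyl. Hydrogen in place of 2-hydroxyethyl gives a 4.0-fold lower number from compound 1 to compound 3 (0.60 log units; beyond the scatter) and leaves compound 1 as the one that stands apart among the three. Nothing available explains these results. As far as these compounds go, whether a methyl group, a longer chain, or a chain ending in an amine or a carboxylic acid would read like butyl or like 2-hydroxyethyl stays open.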